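This account rests on a few compounds, and the source may have more. Where it says the series, first, only, none or still open, it means among the compounds named here.

Compound 1, `O=C(Nc1cccc(F)c1)c1cc(=O)[nH]c2cc(F)ccc12`, sits at the assay limit in a functional assay on KYSE-70 cells for antiproliferative activity against KYSE-70 cell line (Homo sapiens), read by MTT assay, with a stated time of 72 h; a lower number here means a stronger inhibitor, a higher number a weaker inhibitor: > 20000 nM.
Compound 2, `O=C(Nc1cc(F)cc(F)c1)c1cc(=O)[nH]c2cc(F)ccc12`, likewise sits at the limit in this assay: > 20000 nM.
Compound 3, `COc1ccc2c(C(=O)Nc3cc(F)cc(F)c3)cc(=O)[nH]c2n1`, too gives only a limit in this assay: > 20000 nM.

Compound 1 therefore stands only at a limit, with nothing to rank it against the others, since (the limit of > 20000 nM in this assay, at which 3 of the 3 values shown sit). Going by the values given here, the one single-point step, a step that the two limits leave unreadable from compound 1 to compound 2, is unreadable for the same reason. Compound 4, `O=C(Nc1cccc(F)c1)c1cc(=O)[nH]c2cc(C3CC3)ccc12`, differs from compound 1 by cyclopropyl in place of fluoro on an aromatic carbon. Among the compounds with values here, no measured step bears on this change, so the account can only lean on compound 1 staying at the limit. The expected step is a step that the limit leaves unreadable from compound 1 to compound 4, essentially none. Compound 4 is thus estimated at 25000 nM, within 5000 nM to 100000 nM.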

Compound 4, half-maximal inhibitory concentration: > 20000 nM
Compound 4 ended at the assay's limit (the forecaster's own chance of this, stated with the estimate: 70%); the middle value does not contradict the limit.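

No new step can be read between compound 1 and compound 4, since both give only a limit: the limit of > 20000 nM in this assay, at which 4 of the 4 values shown sit.

The compounds shown leave open which change to the shared core, if any, would bring a value within the readable range of this assay.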